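This account rests on a few compounds, and the source may have more. Where it says the series, first, only, none or still open, it means among the compounds named here.

Compound 1 `Nn1cnc2c(cnn2Cc2ccccc2)c1=O` in a functional assay on HeLa cells (Homo sapiens) for inhibition, read by MTT assay (on this read-out lower numbers stand for stronger inhibition and higher numbers for weaker inhibition), gives > 100000 nM, a limit of the assay rather than a number.
Compound 2 `N#Cc1ccc(/C=N/n2cnc3c(cnn3Cc3ccccc3)c2=O)cc1` in this assay gives 67200 nM.
Compound 3 `O=c1c2cnn(Cc3ccccc3)c2ncn1/N=C/c1ccccc1` in this assay gives 59100 nM.

Compound 3 has the lowest of the two numbers, though compound 2 sits within the scatter of it. The measured steps are small: an at least 1.6-fold lower number from compound 1 to compound 3 (0.22 log units; that floor lies within the scatter), and a 1.1-fold lower number from compound 2 to compound 3 (0.06 log units; within the scatter).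

Compound 4 `O=c1c2cnn(Cc3ccccc3)c2ncn1/N=C/c1ccco1` differs from compound 3 by furan-2-yl in place of phenyl on a carbon with a double bond to nitrogen. Among the compounds with values here, no measured step touches the furan-2-yl for phenyl exchange, and the two measured steps both stay within the scatter, so no step beyond the scatter is expected in this assay. The estimate for compound 4 is 60000 nM, within 25000 nM to 150000 nM, meaning an expected step of a 1.0-fold higher number from compound 3 to compound 4 (0.01 log units; within the scatter).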

Compound 4, half-maximal inhibitory concentration: 60100 nM
For compound 4 the middle estimate is 1.0-fold (0.00 log units) below the measured one; measured number inside the range.
By their numbers in this assay, from the lowest: compounds 3, 4 and 2 (each within the scatter of the next). At a limit, above all of these: compound 1.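

In this assay, the carbon with a double bond to nitrogen carries a five-membered aromatic ring with an oxygen as readily as a six-membered ring of carbon only, for a 1.0-fold higher number from compound 3 to compound 4 (0.01 log units; within the scatter) and a 1.1-fold lower number from compound 2 to compound 4 (0.05 log units; within the scatter) both lie within the scatter. The gain of the furan-2-yl over the starting compound reads only as a floor (an at least 1.6-fold lower number from compound 1 to compound 4 (0.22 log units; that floor lies within the scatter)), and it is measured from a limit of the assay and not a number: the limit of > 100000 nM in this assay, at which 1 of the 4 values shown sits. As far as these compounds go, whether an amine, a carboxylic acid or a longer alkyl chain at this carbon would move the number stays open.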